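The source may report more compounds than this note shows. Statements on the series, on what has been measured and on what is new or still open speak of the compounds shown alone.

Among the compounds with values here, compound 2 `CCN(C/C=C/C#CC(C)(C)C)Cc1cccc(OCCN(C)S(=O)(=O)c2cc(Br)cs2)c1` gives 300 nM in a functional assay on HepG2 cells for inhibition of squalene monooxygenase (Homo sapiens) (a lower number here means a stronger inhibitor, a higher number a weaker inhibitor), the highest of the two numbers measured so far. Compound 1 `CCN(C/C=C/C#CC(C)(C)C)Cc1cccc(OCCN(C)S(=O)(=O)c2ccc(C#N)cc2)c1` gives 200 nM, and the step of a 1.5-fold higher number from compound 1 to compound 2 (0.18 log units; within the scatter) lies within the scatter. Compound 3 `CCN(C/C=C/C#CC(C)(C)C)Cc1cccc(OCCN(C)S(=O)(=O)c2ccc(-c3ccsc3)s2)c1` differs from compound 2 by 5-(thiophen-3-yl)thiophen-2-yl in place of 4-bromothiophen-2-yl on a sulfonyl sulfur. Within the data shown here, the only measured step that bears on this change, a 1.5-fold higher number from compound 1 to compound 2 (0.18 log units; within the scatter), also swaps the group on the sulfonyl sulfur and was within the scatter, so no direction is indicated. Compound 3 is therefore expected to give 300 nM, with a range of 100 nM to 900 nM, the expected step of no change at the digits printed from compound 2 to compound 3 (within the scatter) staying within the scatter.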

Compound 3, half-maximal inhibitory concentration: 210 nM
Compound 3: the middle estimate sits 1.4-fold (0.15 log units) above what was measured; measured number inside the range.
By their numbers in this assay, from the lowest: compounds 1, 3 and 2 (each within the scatter of the next).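

With a second five-membered aromatic ring in the group on the sulfonyl sulfur and no bromine, the number in this assay still shows only a 1.4-fold lower number from compound 2 to compound 3 (0.15 log units; within the scatter) and a 1.1-fold higher number from compound 1 to compound 3 (0.02 log units; within the scatter). Three different groups at this place, including one of 10 heavy atoms, therefore give numbers within the scatter of one another. Nothing available explains this insensitivity. Going by these compounds, whether it extends to a group carrying an amine or a carboxylic acid, or to a simple methyl on the sulfonyl sulfur, remains open.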